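A few compounds are considered here, and "the series" means these few. Any claim that something is new, unique, unknown or untested is made for them only; others in the source may bear on it.

Measured in an assay on Sf9 cells for inhibition of serine/threonine-protein kinase 4 (Homo sapiens), read by luminescence and ADP-Glo, with a stated time of 1 h, in the presence of a further agent that is not named here; on this read-out higher numbers stand for weaker inhibition and lower numbers for stronger inhibition: compound 1 `CC(C)C1C(=O)N(C)c2cnc(Nc3ccc(S(N)(=O)=O)cc3)nc2N1C` gives 254 nM; compound 2 `CN1C(=O)C(c2ccccc2)N(C)c2nc(Nc3ccc(S(N)(=O)=O)cc3)ncc21` gives 383 nM; compound 3 `CN1C(=O)C(c2ccccc2Cl)N(C)c2nc(Nc3ccc(S(N)(=O)=O)cc3)ncc21` gives 129 nM.

Compound 3 carries the lowest number of the three. Its separation from compound 1, a 2.0-fold lower number from compound 1 to compound 3 (0.29 log units; within the scatter), stays within the scatter, whereas a 3.0-fold lower number from compound 2 to compound 3 (0.47 log units; beyond the scatter) goes beyond it, a modest step. Compound 4 `CN1C(=O)C(c2ccccc2Br)N(C)c2nc(Nc3ccc(S(N)(=O)=O)cc3)ncc21` differs from compound 3 by bromo in place of chloro on an aromatic carbon. Among the measured compounds shown here, the one measured step at this aromatic carbon is a 3.0-fold lower number from compound 2 to compound 3 (0.47 log units; beyond the scatter), where a halogen replaced hydrogen; no measured pair exchanges one halogen for another. With one halogen giving way to another of similar kind, no step beyond the scatter is expected in this assay. Compound 4 is therefore estimated at 110 nM, with a range from 50 nM to 260 nM. That estimate corresponds to an expected step of a 1.2-fold lower number from compound 3 to compound 4 (0.07 log units; within the scatter).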

Compound 4, half-maximal inhibitory concentration: 57 nM
Compound 4: middle estimate off by 1.9-fold (0.29 log units), on the high side; measured number inside the range.
By their numbers in this assay, from the lowest: compound 4; then compounds 3, 1 and 2 (each within the scatter of the next, the first and the last beyond it).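

Exchanging one halogen for another at this aromatic carbon, ortho to a large group, moves the number beyond the scatter (a 2.3-fold lower number from compound 3 to compound 4 (0.35 log units; beyond the scatter)), so which halogen sits there matters, not only that one is present. Bromo in place of hydrogen also gives a step beyond the scatter (a 6.7-fold lower number from compound 2 to compound 4 (0.83 log units; beyond the scatter)). The 2-bromophenyl group in place of isopropyl does so too (a 4.5-fold lower number from compound 1 to compound 4 (0.65 log units; beyond the scatter)), whereas the step to the 2-chlorophenyl compound 3 stayed within it.

Going by these compounds, whether iodo, methyl or methoxy at this carbon would follow bromo remains open. No measurement shown accounts for the difference between the two halogens.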